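The source may hold more compounds than are shown below. What is called first, only, known or untested is meant among the compounds shown, and "the series" means these compounds.

A small set of three compounds has been measured in a functional assay on DU-145 cells (Homo sapiens) for inhibition, read by trypan blue exclusion, with a stated time of 96 h; on this read-out higher numbers stand for weaker inhibition of growth and lower numbers for stronger inhibition of growth. Compound 1 `Cc1ccc(CS(=O)(=O)/C(=C/c2cc(C)cc(C)c2)C(=O)c2ccc(Cl)cc2)cc1` gives 10000 nM, compound 2 `COc1ccc(/C=C(/SCc2ccc(Cl)cc2)C(=O)c2ccc(Br)cc2)cc1O` gives 1000 nM, and compound 3 `O=C(/C(=C\c1ccc(Br)cc1)Sc1ccc(Br)cc1)c1ccc(Br)cc1` gives 1000 nM. Compound 2 therefore stands level with compound 3, the two together holding the lowest number of the three, while the number for compound 1 is higher by a margin beyond the scatter.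

Compound 4 `O=C(/C(=C\c1ccc(Cl)cc1)SCc1ccc(Cl)cc1)c1ccc(Br)cc1` has not yet been measured in this assay. It departs from compound 2 in one place, where 4-chlorophenyl stands in place of 3-hydroxy-4-methoxyphenyl on a double-bonded chain carbon bound to a double-bonded chain carbon: 4-chlorophenyl in place of 3-hydroxy-4-methoxyphenyl on a double-bonded chain carbon bound to a double-bonded chain carbon.

Among the compounds with values here, no two measured compounds differ in only one place, so the data give no direct measure of this change. Within the data shown here, the only indirect guide is compound 3, which has no 3-hydroxy-4-methoxyphenyl group and still gives 1000 nM. On that basis, the expected result is no change at the digits printed from compound 2 to compound 4 (within the scatter), with no change expected beyond the scatter in either direction. For compound 4 the estimated value is 1000 nM, with an expected range from 300 nM to 5000 nM.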

Compound 4, concentration for 50% growth inhibition: 10000 nM
The estimate for compound 4 lay 10-fold (1.00 log units) below the measured number; measured number outside the range, above it.
By their numbers in this assay, from the lowest: compounds 2 and 3 (each within the scatter of the next); then compounds 1 and 4 (each within the scatter of the next).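

In this assay, within the data shown here, putting 4-chlorophenyl in place of 3-hydroxy-4-methoxyphenyl on a double-bonded chain carbon bound to a double-bonded chain carbon gives a 10-fold higher number from compound 2 to compound 4 (1.00 log units; beyond the scatter), the first change in the set that can be read in one place alone. It shows that, on the core shared by these two compounds, this position is not indifferent to which substituted phenyl group it carries, and that the 3-hydroxy-4-methoxyphenyl group goes with the lower number and so the stronger inhibition of growth of the pair. No supporting measurement is available to say why the number moves with this change.

This single step swaps the hydroxy, the methoxy and the chlorine together, so it does not tell which of them goes with the shift, and a 3-hydroxyphenyl or a 4-methoxyphenyl group at this place would be needed to pull them apart. From the compounds shown here alone, how an aminophenyl or a carboxyphenyl group would read there, and whether the same change holds on other cores, also remains open.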